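This account rests on a few compounds, and the source may have more. Where it says the series, first, only, none or still open, it means among the compounds named here.

Working notes on the series. Compound 1, `O=c1cc(CSc2nc3ccccc3s2)oc2ccccc12`, is tested in a functional assay on HeLa cells (Homo sapiens) for cytotoxicity, read by MTT assay, with a stated time of 72 h; on this read-out higher numbers stand for weaker inhibition and lower numbers for stronger inhibition. In this assay compound 1 gives > 25000 nM, which is a limit of the assay and not a number. Compound 3, `Cc1cc(C)n2nc(SCc3nnc(SCc4cc(=O)c5ccccc5o4)o3)nc2n1`, gives > 25000 nM, again a limit rather than a number. For the measured compounds named here, compound 2, `O=c1c(CSc2cc(=O)c3ccccc3s2)coc2ccccc12`, is the only member with a numerical value, 2600 nM. Compound 1 thus sits at the limit itself: the limit of > 25000 nM in this assay, at which 2 of the 3 values shown sit. Going by the values given here, no step between measured compounds that differ in one place is available, so no measured step size guides the estimate.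

Compound 4, `Cc1ccc2oc(CSc3nc4ccccc4s3)cc(=O)c2c1`, differs from compound 1 by methyl in place of hydrogen on an aromatic carbon. Among the compounds with values here, with no measured step to rest on, the expectation is that this change stays within the scatter; the value of compound 1, > 25000 nM, is expected to carry over as a limit. For compound 4 the estimate in this assay is 30000 nM, with a range from 8000 nM to 120000 nM. The step that this estimate implies, a step that the limit leaves unreadable from compound 1 to compound 4, is expected to be none beyond the scatter, and a limit rather than a number is again the likely outcome.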

Compound 4, half-maximal inhibitory concentration: > 25000 nM
Compound 4 ended at the assay's limit; the forecaster's own chance of this, stated with the estimate: 75%; the middle value is on the limit's open side.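

No step can be read between compound 1 and compound 4, since both values in this assay are limits: the limit of > 25000 nM in this assay, at which 3 of the 4 values shown sit.

The compounds shown leave open whether methyl in place of hydrogen on an aromatic carbon changes the read-out on a core that gives a numerical value.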